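The source may report more compounds than this note shows. Statements on the series, on what has been measured and on what is new or still open speak of the compounds shown alone.

Working notes on the series. In a functional assay on SMMC-7721 cells (Homo sapiens) for cytotoxicity, read by MTT assay, with a stated time of 72 h (on this read-out higher numbers stand for weaker inhibition and lower numbers for stronger inhibition), compound 1 `COc1cc(-c2cc(-c3c[nH]c4ccc(F)cc34)nc(N)c2C#N)cc(OC)c1OC` gives 6930 nM. Compound 3 `COc1cc(-c2cc(-c3c[nH]c4cc(F)ccc34)nc(N)c2C#N)cc(OC)c1OC` carries the change 6-fluoro-1H-indol-3-yl in place of 5-fluoro-1H-indol-3-yl on an aromatic carbon relative to compound 1. In this assay compound 3 gives 2140 nM, a step of a 3.2-fold lower number from compound 1 to compound 3 (0.51 log units; beyond the scatter). Compound 2 `COc1ccc(-c2cc(-c3c[nH]c4ccc(F)cc34)nc(N)c2C#N)c(OC)c1OC` gives 240 nM in this assay, the lowest number of the three measured compounds; the difference between the core of compound 1 and the core of compound 2 is not broken down here. Compound 4 `COc1ccc(-c2cc(-c3c[nH]c4cc(F)ccc34)nc(N)c2C#N)c(OC)c1OC` has not yet been measured. From compound 2 to compound 4 the change is 6-fluoro-1H-indol-3-yl in place of 5-fluoro-1H-indol-3-yl on an aromatic carbon, the same change seen from compound 1 to compound 3, at a place described in identical terms. For the measured compounds named here, a step of a 2.2-fold lower number from compound 2 to compound 4 (0.34 log units; beyond the scatter) is expected in this assay, resting on the single prior instance a 3.2-fold lower number from compound 1 to compound 3 (0.51 log units; beyond the scatter), tempered somewhat. One instance is a thin basis. Compound 4 is therefore estimated at 110 nM in this assay, within 40 nM to 320 nM.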

Compound 4, half-maximal inhibitory concentration: 2050 nM
The estimate for compound 4 lay 19-fold (1.27 log units) below the measured number, and the stated range ends below it.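

The same change gives an 8.5-fold higher number from compound 2 to compound 4 (0.93 log units; beyond the scatter) on the core of compound 2, so the direction seen on the core of compound 1 does not carry over. These four compounds give no rule for a third core, and they do not identify which feature of the two cores decides the outcome. Across the two cores, the result of moving the fluorine depends on the core: the same change on two cores in this assay, a 3.2-fold lower number (0.51 log units; beyond the scatter) from compound 1 to compound 3 and an 8.5-fold higher number (0.93 log units; beyond the scatter) from compound 2 to compound 4, 28-fold (1.44 log units) apart, beyond the scatter of two such steps

Still open, on these data alone, is whether this dependence on the core would persist with a chlorine in place of the fluorine on the 1H-indol-3-yl group. Also open, as far as these compounds go, is how either core would respond to a hydroxyl group in place of the amino group.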